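This account rests on a few compounds, and the source may have more. Where it says the series, first, only, none or still open, it means among the compounds named here.

Of the compounds shown here, two built on one shared core have been measured in a functional assay on MDA-MB-435 cells (Homo sapiens) for inhibition, read by sulforhodamine B assay, with a stated time of 48 h; a lower number here means a stronger inhibitor of growth, a higher number a weaker inhibitor of growth. Compound 1, `COc1cc(C(=O)/C=C/c2c(-c3cccs3)nc3ccccn23)cc(OC)c1OC`, gives 2490 nM, and compound 2, `COc1cc(C(=O)/C=C/c2c(-c3ccc(F)cc3)nc3ncccn23)cc(OC)c1OC`, gives 2360 nM. On these two numbers compound 2 carries the smaller value, yet the gap to compound 1 lies within the scatter of repeated measurements, so the two values cannot truly be told apart. For the measured compounds named here, compounds 1 and 2 differ from each other in more than one place, so no single step between them can be read from this pair.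

Compound 3, `COc1ccc(-c2nc3ncccn3c2/C=C/C(=O)c2cc(OC)c(OC)c(OC)c2)cc1`, has not yet been measured. It differs from compound 2 in one place only: methoxy in place of fluoro on an aromatic carbon. Going by the values given here, no measured pair shows what this change does on the shared core, so the expectation rests on compound 2 alone. In this assay the step is expected to be a 1.6-fold lower number from compound 2 to compound 3 (0.20 log units; within the scatter), a small move toward a lower number that is not clearly beyond the scatter. Compound 3 is therefore estimated at 1500 nM, with a likely range from 500 nM to 4500 nM.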

Compound 3, concentration for 50% growth inhibition: 2280 nM
For compound 3 the middle estimate is 1.5-fold (0.18 log units) below the measured one, and the stated range covers the measured number.
By their numbers in this assay, from the lowest: compounds 3, 2 and 1 (each within the scatter of the next).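

In this assay, for the compounds shown here, the change from 4-fluorophenyl to 4-methoxyphenyl gives a 1.0-fold lower number from compound 2 to compound 3 (0.01 log units; within the scatter) and is the first single-place step that can be read on the shared core. At this place, para to a large group on the six-membered aromatic ring of carbon only, methoxy and fluoro cannot be told apart, even though methoxy brings two heavy atoms and one hydrogen-bond acceptor where fluoro brings one heavy atom and none. Nothing available here speaks to the reason for this result.

The compounds shown leave open whether a different kind of group at this place, such as an amine, a carboxylic acid or a longer chain, would move the number beyond the scatter. From the compounds shown here alone, compound 1 differs from both compound 2 and compound 3 in more than one place, so those steps cannot be read, and it remains open whether the same change would behave alike on the core of compound 1.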